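A few compounds are considered here, and "the series" means these few. Any claim that something is new, unique, unknown or untested is made for them only; others in the source may bear on it.

Compound 3 `CCCS(=O)(=O)N1CC=C(c2ccc3c(c2)CC(C2CCN(c4ncc(C(F)(F)F)cn4)CC2)O3)CC1` stands highest of the three measured compounds in a functional assay on HEK293 cells with Glucose-dependent insulinotropic receptor (Homo sapiens) as the target, read by cAMP accumulation, with a stated time of 60 min (a lower number here means a smaller maximal response, a higher number a larger maximal response), with 118%. Compound 1 `CCCS(=O)(=O)N1CC=C(c2ccc3c(c2)CC(C2CCN(S(=O)(=O)CCC)CC2)O3)CC1` gives 43% and compound 2 `CCCS(=O)(=O)N1CC=C(c2ccc3c(c2)CC(C2CCN(C(=O)OC4CCCCC4)CC2)O3)CC1` gives 56%, so the steps of a number 75 percentage points higher from compound 1 to compound 3 (beyond the scatter) and a number 62 percentage points higher from compound 2 to compound 3 (beyond the scatter) are large, while a number 13 percentage points higher from compound 1 to compound 2 (beyond the scatter) is modest. All three steps change the group on the ring nitrogen, not the group on the pyrimidine, so none bears directly on the change to compound 4 `CCCS(=O)(=O)N1CC=C(c2ccc3c(c2)CC(C2CCN(c4ncc(C5CC5)cn4)CC2)O3)CC1`: cyclopropyl in place of trifluoromethyl on an aromatic carbon. Among the measured compounds shown here, with no step of this kind measured, only a small step within the usual scatter is expected, as a number 10 percentage points lower from compound 3 to compound 4 (within the scatter). Compound 4 is therefore expected to give about 108%, between 80% and 130%.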

Compound 4, largest response reached (Emax), in percent of the reference or control that the assay uses: 85%
Beside the measured number, compound 4's estimate is 23 percentage points above it; the measured number falls inside the stated range.
By their numbers in this assay, from the lowest: compound 1; then compound 2; then compound 4; then compound 3.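

In this assay, the substituent on the pyrimidine matters in its own right: swapping trifluoromethyl for cyclopropyl, with the rest of the molecule unchanged, gives a number 33 percentage points lower from compound 3 to compound 4 (beyond the scatter) as a large step. The 5-cyclopropylpyrimidin-2-yl group still outperforms both other groups on the ring nitrogen, with a number 29 percentage points higher from compound 2 to compound 4 (beyond the scatter) against cyclohexyloxycarbonyl and a number 42 percentage points higher from compound 1 to compound 4 (beyond the scatter) against propylsulfonyl. No supporting evidence explains the drop from this swap. Two compounds cannot show how this position responds more generally. A chlorine atom, a methoxy group or an ethyl chain there would show whether other groups also give a smaller maximal response than trifluoromethyl.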